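Chloro for fluoro on an aromatic carbon of the aryl ring

The compounds below may be only part of what the source reports. "The series", "measured", "known", "first", "only" and "open" are said of these compounds alone.

Among the measured compounds shown here, compound 3 `O=C(CCCN1CCN(c2ccc(F)cc2)CC1)Nc1ccc(Cl)cc1` gives 3490 nM in an assay on HEK293 cells for inhibition of Voltage-dependent T-type calcium channel subunit alpha-1G (Homo sapiens), read by patch clamp (on this read-out lower numbers stand for stronger inhibition and higher numbers for weaker inhibition), and stands at the low end of the three numbers so far; compound 2 `O=C(CCCN1CCN(c2ccccc2F)CC1)Nc1ccc(Cl)cc1` gives 3630 nM and compound 1 `O=C(CCCN1CCN(c2ccccc2)CC1)Nc1ccc(Cl)cc1` gives 4470 nM, and both sit within the scatter of compound 3. Compound 4 `O=C(CCCN1CCN(c2ccc(Cl)cc2)CC1)Nc1ccc(Cl)cc1` differs from compound 3 by chloro in place of fluoro on an aromatic carbon. For the measured compounds named here, the steps that bear on this site are the two halogen introductions, a 1.3-fold lower number from compound 1 to compound 3 (0.11 log units; within the scatter) and a 1.2-fold lower number from compound 1 to compound 2 (0.09 log units; within the scatter), and the shift of the fluoro, a 1.0-fold lower number from compound 2 to compound 3 (0.02 log units; within the scatter); none of them left the scatter. Nothing measured here separates one halogen from another at this carbon, so in this assay no step beyond the scatter is expected for compound 4, with at most a slight drift toward lower numbers as a possibility. Compound 4 is therefore estimated at 2800 nM, range 1200 nM to 6500 nM, which means an expected step of a 1.2-fold lower number from compound 3 to compound 4 (0.10 log units; within the scatter).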

Compound 4, half-maximal inhibitory concentration: 2640 nM
Beside the measured number, compound 4's estimate is 1.1-fold (0.03 log units) above it; the measured number falls inside the stated range.
By their numbers in this assay, from the lowest: compounds 4, 3, 2 and 1 (each within the scatter of the next).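

In this assay, chloro in place of fluoro at this carbon, para to a large group, stays within the scatter (a 1.3-fold lower number from compound 3 to compound 4 (0.12 log units; within the scatter)), and the comparison with the 2-fluorophenyl compound also stays within it (a 1.4-fold lower number from compound 2 to compound 4 (0.14 log units; within the scatter)). Chloro in place of hydrogen gives the same reading (a 1.7-fold lower number from compound 1 to compound 4 (0.23 log units; within the scatter)), so this position now tolerates a second halogen, chloro as well as fluoro, without a step beyond the scatter. No measurement here bears on why hydrogen, fluoro and chloro read alike at this carbon.

Going by these compounds, whether a group of another kind at this carbon, such as methoxy, trifluoromethyl or an amine, would leave the scatter remains open. So does the effect of a longer chain in the shared core, or of a replacement for the chloro on the anilide ring.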